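Triazole to tetrazole on the chain beside the carbonyl

The compounds below may be only part of what the source reports. "The series", "measured", "known", "first", "only" and "open" are said of these compounds alone.

Compound 1 `CCCCCCCCc1ccc(OCC(=O)Cn2nnc3cccnc32)cc1`: in an assay on microsomes from brain for inhibition of Fatty-acid amide hydrolase 1 (Rattus norvegicus), read by fluorescence and HPLC, with a stated time of 60 min (on this read-out lower numbers stand for stronger inhibition and higher numbers for weaker inhibition), compound 1 gives 13 nM.
Compound 2 `CCCCCCCCc1ccc(OCC(=O)Cn2ccc3ncccc32)cc1`: compound 2 reaches only the limit > 10000 nM, which is a limit and not a number (the limit of > 10000 nM in this assay, at which 1 of the 3 values shown sits).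
Compound 3 `CCCCCCCCc1ccc(OCC(=O)Cn2nccn2)cc1`: compound 3 gives 100 nM.

Among the two numbers, compound 3 holds the higher one; the step of a 7.7-fold higher number from compound 1 to compound 3 (0.89 log units; beyond the scatter) is modest, while an at least 100-fold lower number from compound 2 to compound 3 (2.00 log units; beyond the scatter) is large. Compound 4 `CCCCCCCCc1ccc(OCC(=O)Cn2cnnn2)cc1` differs from compound 3 by 1H-tetrazol-1-yl in place of 2H-1,2,3-triazol-2-yl on a saturated chain carbon bound to a carbonyl carbon. Within the data shown here, no measured step exchanges one five-membered ring for another of the same size; the steps to compound 3 all replace a larger bicyclic group, so they bear on this change only loosely. A step in this assay no larger than the modest range is therefore expected, with slight weakening more likely than gain. Compound 4 is estimated at 250 nM, between 60 nM and 1000 nM, which means an expected step of a 2.5-fold higher number from compound 3 to compound 4 (0.40 log units; beyond the scatter).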

Compound 4, half-maximal inhibitory concentration: 39 nM
For compound 4 the middle estimate is 6.4-fold (0.81 log units) above the measured one; the measured number lies below the stated range.
By their numbers in this assay, from the lowest: compound 1; then compound 4; then compound 3. At a limit, above all of these: compound 2.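

In this assay, the exchange of one five-membered ring for another at this position is now seen directly: a 2.6-fold lower number from compound 3 to compound 4 (0.41 log units; beyond the scatter), a modest gain from 1H-tetrazol-1-yl in place of 2H-1,2,3-triazol-2-yl. The larger group on the same carbon still keeps an edge, with a 3.0-fold higher number from compound 1 to compound 4 (0.48 log units; beyond the scatter). The widest step, an at least 250-fold lower number from compound 2 to compound 4 (2.40 log units; beyond the scatter), starts from a limit and not a number: the limit of > 10000 nM in this assay, at which 1 of the 4 values shown sits.

This single pair cannot show whether the gain follows the count of ring nitrogens. An imidazol-1-yl or pyrazol-1-yl group on this chain carbon remains an open case.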